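The source may hold more compounds than are shown below. What is called first, only, known or untested is meant among the compounds shown, and "the series" means these compounds.

Three compounds share one core. Compound 1 `Cc1cc(Br)c(S(C)(=O)=O)cc1C(=O)N=C(N)N` gives 12 nM in a functional assay for inhibition of sodium/hydrogen exchanger (Oryctolagus cuniculus); a higher number here means a weaker inhibitor, a lower number a stronger inhibitor. Compound 2 `CCCSc1cc(C)c(C(=O)N=C(N)N)cc1S(C)(=O)=O` gives 6.8 nM, and compound 3 `Cc1cc(SC(C)C)c(S(C)(=O)=O)cc1C(=O)N=C(N)N` gives 12 nM. On these numbers compound 3 sits level with compound 1, and the step of a 1.8-fold higher number from compound 2 to compound 3 (0.25 log units; within the scatter) is within the scatter. Compound 4 `CCOc1cc(C)c(C(=O)N=C(N)N)cc1S(C)(=O)=O` differs from compound 3 by ethoxy in place of isopropylsulfanyl on an aromatic carbon. Among the compounds with values here, the steps that bear on this place are no change at the digits printed from compound 1 to compound 3 (within the scatter) and a 1.8-fold lower number from compound 1 to compound 2 (0.25 log units; within the scatter); neither left the scatter, so three different groups at this aromatic carbon gave one number within scatter of each other. Compound 4 is therefore expected to show a 1.2-fold lower number from compound 3 to compound 4 (0.08 log units; within the scatter), nothing beyond the scatter. The estimate for compound 4 is 10 nM, within 4 nM to 30 nM.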

Compound 4, half-maximal inhibitory concentration: 19 nM
Compound 4: the middle estimate sits 1.9-fold (0.28 log units) below what was measured, within the range that was stated.
By their numbers in this assay, from the lowest: compounds 2, 1, 3 and 4 (each within the scatter of the next, the first and the last beyond it).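

In this assay ethoxy, which brings oxygen where the earlier groups had sulfur or bromo, gives a 1.6-fold higher number from compound 3 to compound 4 (0.20 log units; within the scatter) and a 1.6-fold higher number from compound 1 to compound 4 (0.20 log units; within the scatter) and so stays within the scatter of those two groups. Against propylsulfanyl it gives a 2.8-fold higher number from compound 2 to compound 4 (0.45 log units; beyond the scatter) as the first step at this aromatic carbon to leave the scatter, so this place is not wholly indifferent to its group, though the step is modest. No measurement given here accounts for that step.

From the compounds shown here alone, whether the gap goes with the oxygen or with the shorter chain stays open, and propoxy or ethylsulfanyl would separate the two. Going by these compounds, how an amine or a carboxylic acid would read at this carbon also stays open.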